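A Methyl Added to Compound 1

The source may hold more compounds than are shown below. What is called first, only, known or untested is meant among the compounds shown, and "the series" means these compounds.

Compound 1 `COc1ccc2c(OCC[C@@H]3NC(=O)N(C)CCCC/C=C\[C@@H]4C[C@@]4(C(=O)NS(=O)(=O)C4(C)CC4)NC3=O)cc(-c3nc(C(C)C)cs3)nc2c1` gives 6500 nM
Compound 2 `C#C[C@@H]1CCCN1S(=O)(=O)NC(=O)[C@@]12C[C@H]1/C=C\CCCCN(C)C(=O)N[C@@H](CCOc1cc(-c3nc(C(C)C)cs3)nc3c(Cl)c(OC)ccc13)C(=O)N2` gives 21200 nM

In an ADME assay on cells (Homo sapiens) for activation (a lower number here means that less compound is tolerated, a higher number that more compound is tolerated), compound 1 holds the lower of the two numbers, beyond the scatter from compound 2. Compound 3 `COc1ccc2c(OCC[C@@H]3NC(=O)N(C)CCCC/C=C\[C@@H]4C[C@@]4(C(=O)NS(=O)(=O)C4(C)CC4)NC3=O)cc(-c3nc(C(C)C)cs3)nc2c1C` differs from compound 1 by methyl in place of hydrogen on an aromatic carbon with methyl in place of hydrogen on an aromatic carbon. Within the data shown here, no measured pair isolates this change, and compound 2 differs from compound 1 in other ways, so compound 2 at 21200 nM is only a loose guide. A slight upward step within the scatter is expected, and the estimated 1.2-fold higher number from compound 1 to compound 3 (0.09 log units; within the scatter) stays small. Compound 3 is expected at 8000 nM with an estimated range from 3500 nM to 20000 nM in this assay.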

Compound 3, half-maximal cytotoxic concentration: 31900 nM
For compound 3 the middle estimate is 4.0-fold (0.60 log units) below the measured one, outside the stated range (above it).
By their numbers in this assay, from the lowest: compound 1; then compounds 2 and 3 (each within the scatter of the next).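

In this assay the methyl in place of hydrogen on an aromatic carbon gives a 4.9-fold higher number from compound 1 to compound 3 (0.69 log units; beyond the scatter) and thereby shows that this single position, ortho to a methoxy group, can by itself move the number beyond the scatter. The earlier compounds shown here isolated no such change. Nothing measured here explains the step. Going by these compounds, whether an ethyl, a trifluoromethyl or an amine on this same carbon would move the number in the same direction stays open. So does whether the methyl would have the same effect on a different core.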